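Swapping ethylamino for pyrrolidin-1-yl on compound 3

This account rests on a few compounds, and the source may have more. Where it says the series, first, only, none or still open, it means among the compounds named here.

- compound 1 `CCOC(=O)Nc1cccc2c1CN(C)CC2c1ccc(F)cc1`: 3.5 mg/kg
- compound 2 `CN1Cc2c(NC(=O)OCc3ccccc3)cccc2C(c2ccccc2)C1`: about 15 mg/kg
- compound 3 `CCNCC(=O)Nc1cccc2c1CN(C)CC2c1ccccc1`: 47 mg/kg

In a functional assay on the whole organism for inhibition, with Mus musculus as the target (on this read-out higher numbers stand for an effect only at larger amounts of compound and lower numbers for an effect already at smaller amounts), compound 3 gives 47 mg/kg, the highest of the three numbers, so it needs the largest dose of the set. Compound 4 `CN1Cc2c(NC(=O)CN3CCCC3)cccc2C(c2ccccc2)C1` has not yet been measured. It keeps the core of compound 3 and changes one group: pyrrolidin-1-yl in place of ethylamino on a saturated chain carbon bound to a carbonyl carbon. The ethylamino group thus gives way to a five-membered ring that lacks the hydrogen-bond donor.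

For the measured compounds named here, only one measured step touches this part of the molecule: a 3.1-fold higher number from compound 2 to compound 3 (0.50 log units; beyond the scatter). That step replaced benzyloxy with (ethylamino)methyl on the carbonyl carbon, a different exchange from this one. Going by the values given here, no measured pair compares ethylamino with pyrrolidin-1-yl, so the data give no direction for this swap. In this assay no step beyond the usual scatter is therefore expected, and the wide range reflects that uncertainty. The expected change is a 1.2-fold lower number from compound 3 to compound 4 (0.07 log units; within the scatter). For compound 4 the estimated value is 40 mg/kg, with an expected range of 14 mg/kg to 110 mg/kg.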

Compound 4, dose for half-maximal effect: 39 mg/kg
Compound 4: middle estimate off by 1.0-fold (0.01 log units), on the high side; the measured number falls inside the stated range.
By their numbers in this assay, from the lowest: compound 1; then compound 2; then compounds 4 and 3 (each within the scatter of the next).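

In this assay the exchange of ethylamino for pyrrolidin-1-yl gives a 1.2-fold lower number from compound 3 to compound 4 (0.08 log units; within the scatter) and so leaves the dose unchanged within the scatter, even though the hydrogen-bond donor of ethylamino is gone and the amine now sits in a five-membered ring. Replacing benzyloxy with (pyrrolidin-1-yl)methyl on a carbonyl carbon gives a 2.6-fold higher number from compound 2 to compound 4 (0.41 log units; beyond the scatter) and the ethylamino counterpart gives a 3.1-fold higher number from compound 2 to compound 3 (0.50 log units; beyond the scatter) in the same direction, so both amine groups shown need a larger dose than benzyloxy. Nothing available explains this behaviour.

A six-membered piperidin-1-yl ring or a morpholin-4-yl ring, with its added oxygen, could show whether ring size or a second hetero atom matters here. Going by these compounds, a longer chain carrying the amine also remains open.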